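Urea aryl trimming in the shared core series

A few compounds are considered here, and "the series" means these few. Any claim that something is new, unique, unknown or untested is made for them only; others in the source may bear on it.

Compound 1 `O=C(Nc1cccc(-n2cc(-c3ccncc3)c(-c3ccc(Cl)c(O)c3)n2)c1)Nc1cc(C(F)(F)F)cc(C(F)(F)F)c1` gives the lowest of the two numbers in a functional assay on SK-MEL-2 cells (Homo sapiens) for inhibition, read by sulforhodamine B assay, with a stated time of 48 h (on this read-out lower numbers stand for higher toxicity in this test and higher numbers for lower toxicity in this test), namely 14100 nM, with compound 2 `COc1cc(-c2nn(-c3cccc(NC(=O)Nc4ccc(Cl)c(C(F)(F)F)c4)c3)cc2-c2ccncc2)ccc1Cl` close at 17500 nM, within the scatter. Compound 3 `COc1cc(-c2nn(-c3cccc(NC(=O)c4ccccc4)c3)cc2-c2ccncc2)ccc1Cl` reaches only the limit > 100000 nM in this assay. Among the compounds with values here, the one measured step, an at least 5.7-fold higher number from compound 2 to compound 3 (0.75 log units; beyond the scatter), sits on a different part of the molecule and rests on (the limit of > 100000 nM in this assay, at which 1 of the 3 values shown sits). Compound 4 `O=C(Nc1cccc(-n2cc(-c3ccncc3)c(-c3ccc(Cl)c(O)c3)n2)c1)Nc1cccc(C(F)(F)F)c1` differs from compound 1 by hydrogen in place of trifluoromethyl on an aromatic carbon. Compound 1 and compound 2 show that changing substituents on the terminal aryl of the urea leaves the number within the scatter, so for compound 4 a step of about a 1.4-fold higher number from compound 1 to compound 4 (0.15 log units; within the scatter) is expected, at most a modest rise. Compound 4 is estimated at 20000 nM, between 8000 nM and 60000 nM.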

Compound 4, concentration lethal to 50% of the cells: > 32500 nM
Compound 4 was reported as a limit (the forecaster's own chance of this, stated with the estimate: 15%); middle value at least 1.6-fold (0.21 log units) from the limit.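

In this assay, within the data shown here, this is the first step read directly on the terminal aryl of the urea, since compound 1 and compound 2 differ in more than one place: an at least 2.3-fold higher number from compound 1 to compound 4 (0.36 log units; beyond the scatter). Hydrogen in place of trifluoromethyl on this aromatic carbon therefore moves the number beyond the scatter, towards lower toxicity in this test. Compound 4 is reported as a limit, so only a lower bound on the step can be read: the limit of > 32500 nM in this assay, at which 1 of the 4 values shown sits.

From the compounds shown here alone, the full size of the step remains open. Going by these compounds, it is also open whether an amine or a methyl group on this carbon would keep the number close to that of compound 1.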